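This account rests on a few compounds, and the source may have more. Where it says the series, first, only, none or still open, it means among the compounds named here.

Compound 1 `COc1ccc(N(C)c2nc(C)nc3ccccc23)cc1C(=O)OCCC[Se]C#N`: 1180 nM
Compound 2 `CN(c1ccc([Se]C#N)cc1)c1nc(C2CC2)nc2ccccc12`: 29 nM
Compound 3 `C[Se]c1ccc(N(C)c2nc(C)nc3ccccc23)cc1Cl`: 7 nM

All three were tested in a functional assay on MDA-MB-231 cells (Homo sapiens) for inhibition, read by MTT assay, with a stated time of 48 h; a lower number here means a stronger inhibitor, a higher number a weaker inhibitor. Among them compound 1 has the highest number and is therefore the weakest; compound 2 sits well below it, and compound 3 lower still, both gaps beyond the scatter. Compound 4 `COc1ccc(N(C)c2nc(C)nc3ccccc23)cc1[Se]C` has not been measured. It differs from compound 1 in one place: a group of 2 heavy atoms (1 carbon, 1 selenium; no ring) in place of a group of 9 heavy atoms (5 carbon, 1 nitrogen, 2 oxygen, 1 selenium; no ring), on an aromatic carbon The group that enters is the same small one carried by compound 3, which gives 7 nM. Within the data shown here, no step between measured compounds is available, so the expectation rests on this likeness. The step of a 59-fold lower number from compound 1 to compound 4 (1.77 log units; beyond the scatter) is expected to be large, toward a lower number. Compound 4 is expected to reach 20 nM, within a range of 5 nM to 80 nM.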

Compound 4, half-maximal inhibitory concentration: 10 nM
Beside the measured number, compound 4's estimate is 2.0-fold (0.30 log units) above it; measured number inside the range.
By their numbers in this assay, from the lowest: compounds 3 and 4 (each within the scatter of the next); then compound 2; then compound 1.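

Among these compounds, this is the first direct one-place comparison: in this assay, replacing the group of 9 heavy atoms with the group of 2 heavy atoms, one carbon and one selenium, on this aromatic carbon ortho to a methoxy group gives a 120-fold lower number from compound 1 to compound 4 (2.07 log units; beyond the scatter). So at this position, the large group carries a heavy cost that the small one does not. No measurement at hand explains the size of this step. Going by these compounds, whether a methylthio group, with sulfur in place of selenium, would serve equally well here remains open. So does how a carboxylic acid at this position would compare.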